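A few compounds are considered here, and "the series" means these few. Any claim that something is new, unique, unknown or untested is made for them only; others in the source may bear on it.

Measured so far:
compound 1 `Cc1oc2c3c(ccc2c(=O)c1C)OC[C@H]1[C@@H]3c2c(ccc(C(=O)c3ccccc3)c2O)OC1(C)C`: > 100000 nM
compound 2 `Cc1coc2c3c(ccc2c1=O)OC[C@H]1[C@@H]3c2c(ccc(C(=O)Cc3ccccc3)c2O)OC1(C)C`: > 100000 nM

In a functional assay on MCF7 cells (Homo sapiens) for cytotoxicity, read by MTT assay (on this read-out higher numbers stand for weaker inhibition and lower numbers for stronger inhibition), compound 1 gives > 100000 nM, which is a limit of the assay and not a number. Compound 2 likewise gives > 100000 nM, again only a limit. Going by the values given here, compound 2 therefore stands at the assay limit, as does the one other value shown (the limit of > 100000 nM in this assay, at which 2 of the 2 values shown sit). Compound 3 `Cc1coc2c3c(ccc2c1=O)OC[C@H]1[C@@H]3c2c(ccc(C(=O)c3ccccc3)c2O)OC1(C)C` has not been measured; it differs from compound 2 by phenyl in place of benzyl on a carbonyl carbon, read one bond further out as benzylcarbonyl to benzoyl. Among the compounds with values here, no measured step tracks this change. The expected step of a number no higher from compound 2 to compound 3 (the limit leaves the size open) is none beyond the scatter, most likely another limit. Compound 3 is estimated at 100000 nM, in the range 40000 nM to 250000 nM.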

Compound 3, half-maximal inhibitory concentration: 6240 nM
The estimate for compound 3 lay 16-fold (1.20 log units) above the measured number; the whole stated range lies above it.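

In this assay, this carbonyl position and the neighbouring methyl both matter: phenyl in place of benzyl on a carbonyl carbon gives an at least 16-fold lower number from compound 2 to compound 3 (1.20 log units; beyond the scatter). Hydrogen in place of methyl on an aromatic carbon gives an at least 16-fold lower number from compound 1 to compound 3 (1.20 log units; beyond the scatter). Only the combination in compound 3 gives a readable number, while compound 1 and compound 2 each keep one of the two groups and stay at a limit: the limit of > 100000 nM in this assay, at which 2 of the 3 values shown sit.

On these data alone, the full size of both steps stays open, as each starts from a limit. Also open, as far as these compounds go, is whether an amine or a carboxylic acid in place of phenyl on the carbonyl carbon would lower the number further.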